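This account rests on a few compounds, and the source may have more. Where it says the series, first, only, none or still open, it means among the compounds named here.

In a functional assay for inhibition, with Homo sapiens as the target (on this read-out lower numbers stand for stronger inhibition and higher numbers for weaker inhibition), compound 2 `COc1cc(OC)c(C(=O)/C=C/c2ccncc2)c(OC)c1` gives 592 nM and compound 1 `COc1cc(OC)c(C(=O)/C=C/c2c(Cl)cccc2Cl)c(OC)c1` gives 1090 nM; the two numbers stand within the scatter of each other. Compound 3 `COc1cc(OC)c(C(=O)/C=C/c2cnccn2)c(OC)c1` carries pyrazin-2-yl in place of pyridin-4-yl on a double-bonded chain carbon bound to a double-bonded chain carbon. For the measured compounds named here, the only measured step at this place, a 1.8-fold lower number from compound 1 to compound 2 (0.27 log units; within the scatter), stays within the scatter, so no step beyond the scatter is expected in this assay, in either direction. The estimated change is a 1.2-fold higher number from compound 2 to compound 3 (0.07 log units; within the scatter). The expected value for compound 3 is 700 nM, with an estimated range from 250 nM to 2000 nM.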

Compound 3, half-maximal inhibitory concentration: 693 nM
Beside the measured number, compound 3's estimate is 1.0-fold (0.00 log units) above it; measured number inside the range.
By their numbers in this assay, from the lowest: compounds 2, 3 and 1 (each within the scatter of the next).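

In this assay, pyrazin-2-yl in place of pyridin-4-yl gives a 1.2-fold higher number from compound 2 to compound 3 (0.07 log units; within the scatter) and pyrazin-2-yl in place of 2,6-dichlorophenyl gives a 1.6-fold lower number from compound 1 to compound 3 (0.20 log units; within the scatter) with both steps within the scatter. On a double-bonded chain carbon bound to a double-bonded chain carbon, all three six-membered aromatic rings shown, with 0, 1 or 2 hetero atoms, therefore give numbers that cannot be told apart. No measurement on hand explains this flat result.

On these data alone, whether any group at this place gives a step beyond the scatter stays open. A primary amine, a carboxylic acid or a saturated piperidine ring there would test this.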